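The compounds below may be only part of what the source reports. "The series", "measured", "known", "first", "only" and "open" are said of these compounds alone.

Compound 1, `CCOC(=O)N1CCN(C(=S)SCC(O)Cn2c([N+](=O)[O-])cnc2C)CC1`, and compound 2, `Cc1ncc([N+](=O)[O-])n1CC(O)CSC(=S)N1CCCCC1`, were both tested in a toxicity assay on HeLa cells (Homo sapiens) for cytotoxicity, read by MTT assay, with a stated time of 24 h; a higher number here means a weaker inhibitor, a lower number a stronger inhibitor. There compound 1 gives 1610000 nM, and compound 2 gives 1400000 nM; the gap between those two numbers lies within the usual scatter, so neither can be set apart from the other. Compound 3, `CCCCN1CCN(C(=S)SCC(O)Cn2c([N+](=O)[O-])cnc2C)CC1`, has not yet been measured. It differs from compound 1 in a single place: butyl in place of ethoxycarbonyl on an amine nitrogen in a ring. Within the data shown here, no measured pair shows this change, so the step from compound 1 to compound 3 in this assay is expected to be small, most likely none beyond the scatter, which is what a 1.2-fold lower number from compound 1 to compound 3 (0.09 log units; within the scatter) means. Compound 3 is therefore estimated at 1300000 nM, between 500000 nM and 3200000 nM.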

Compound 3, half-maximal inhibitory concentration: 1910000 nM
Estimate against measurement, compound 3: 1.5-fold (0.17 log units) below; the range from low to high includes it.
By their numbers in this assay, from the lowest: compounds 2, 1 and 3 (each within the scatter of the next).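

Butyl in place of ethoxycarbonyl on an amine nitrogen in a ring gives a 1.2-fold higher number from compound 1 to compound 3 (0.07 log units; within the scatter) in this assay. At this position, then, a group with 2 hydrogen-bond acceptors and a chain with none cannot be told apart in this assay. Nothing available explains why these two groups read alike. Both groups on this nitrogen have no ring and no net charge. As far as these compounds go, it remains open whether a phenyl ring or a carboxylic acid at the same place would shift the number beyond the scatter.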